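This account rests on a few compounds, and the source may have more. Where it says the series, first, only, none or still open, it means among the compounds named here.

Three compounds have been measured in a functional assay on SF-539 cells (Homo sapiens) for cytotoxicity, read by sulforhodamine B assay, with a stated time of 48 h, tested at 0.01 uM; a lower number here means a stronger effect, a higher number a weaker effect of the compound at the concentration tested:

compound 1 `COc1cc(-c2cc(/C=C/C(=O)c3ccc(N)cc3)[nH]n2)cc(OC)c1OC` gives 92%
compound 2 `COc1ccc(-c2cc(/C=C/C(=O)c3ccc(OC)c(OC)c3)[nH]n2)cc1` gives 95%
compound 3 `COc1cc(-c2cc(/C=C/C(=O)c3ccc(Cl)c(Cl)c3)[nH]n2)cc(OC)c1OC` gives 93%

Compound 1 holds the lowest of the three numbers, yet its gap to compound 3 is a number 1 percentage points higher from compound 1 to compound 3 (within the scatter), and compound 2 sits only slightly higher still, so all three lie within the scatter of one another. Compound 4 `COc1ccc(-c2cc(/C=C/C(=O)c3ccc(N)cc3)[nH]n2)cc1OC` differs from compound 1 by hydrogen in place of methoxy on an aromatic carbon. Among the measured compounds shown here, no measured step touches this ring; the only step known, a number 1 percentage points higher from compound 1 to compound 3 (within the scatter), concerns the group on the carbonyl carbon and stayed within the scatter. Nothing therefore points to a change beyond the scatter in this assay, and compound 4 is expected to give 93% (range 84% to 100%), a step of a number 1 percentage points higher from compound 1 to compound 4 (within the scatter).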

Compound 4, a percentage reported as activity, at one concentration (the size of the read-out at that concentration, not a potency): 93%
The estimate for compound 4 equals the measured number at the digits printed; low and high end bracket the measured number.
By their numbers in this assay, from the lowest: compounds 1, 3, 4 and 2 (each within the scatter of the next).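

Hydrogen in place of methoxy is the first replacement shown on this ring, at the aromatic carbon ortho to a methoxy group and meta to a large group. In this assay it gives a number 1 percentage points higher from compound 1 to compound 4 (within the scatter), so the read-out at this single concentration does not separate the compounds with and without this methoxy. No measurement given here bears on the reason for this result. The compounds shown leave open whether a hydroxyl, a fluorine or an ethoxy at this carbon would move the read-out beyond the scatter. They also leave open whether compound 1 and compound 4 would differ at higher concentrations.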